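A few compounds are considered here, and "the series" means these few. Any claim that something is new, unique, unknown or untested is made for them only; others in the source may bear on it.

Measured in a functional assay on NCI-H460 cells (Homo sapiens) for inhibition; a higher number here means that more compound is needed for the effect, a lower number that less compound is needed:
- Compound 1 `C[C@@H](Cc1ccccc1)C(=O)SCCCCCCC(=O)Nc1nc(-c2ccccc2)cs1`: 3000 nM
- Compound 2 `CC(Cc1ccccc1)C(=O)SCCCCCCC(=O)Nc1nc(-c2ccccc2)cs1`: 1500 nM

Within the data shown here, compound 2 cannot be told apart from compound 1 on these numbers, since the one measured step, a 2.0-fold lower number from compound 1 to compound 2 (0.30 log units; within the scatter), lies within the scatter. That step concerns only (the fact that one of compounds 1 and 2 is drawn with a defined configuration and the other without, at the place where they differ).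

Compound 3 `COC(C(=O)SCCCCCCC(=O)Nc1nc(-c2ccccc2)cs1)c1ccccc1` carries methoxy(phenyl)methyl in place of 1-benzylethyl on a carbonyl carbon. The measured step involves no change of group, so it gives no direct measure of this replacement and indicates no direction. It shows only how closely the two measured values agree. In this assay, no step beyond the scatter is therefore expected, although the uncertainty is wide.

The expected change is a 1.3-fold higher number from compound 2 to compound 3 (0.12 log units; within the scatter). The estimate for compound 3 is 2000 nM, with an expected range from 600 nM to 6500 nM.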

Compound 3, half-maximal effective concentration: 11000 nM
The estimate for compound 3 lay 5.5-fold (0.74 log units) below the measured number; measured number outside the range, above it.
By their numbers in this assay, from the lowest: compounds 2 and 1 (each within the scatter of the next); then compound 3.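

In this assay, the place on a carbonyl carbon whose other neighbour is sulfur proves sensitive to a change of group: methoxy(phenyl)methyl in place of 1-benzylethyl gives a 7.3-fold higher number from compound 2 to compound 3 (0.87 log units; beyond the scatter), and likewise a 3.7-fold higher number from compound 1 to compound 3 (0.56 log units; beyond the scatter). The earlier pair differed only in how a stereocentre was drawn, whereas this replacement moves the number beyond the scatter, even though both groups have 9 heavy atoms and one six-membered aromatic ring, and the entering group adds an oxygen and a hydrogen-bond acceptor. What is known about these compounds gives no cause for this step.

The compounds shown leave open whether the oxygen itself matters or the way the groups are arranged around the carbon. They also leave open how a hydroxy group or an amine would fare in place of the methoxy group.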